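The compounds below may be only part of what the source reports. "The series", "measured", "known", "first", "only" and "open" are said of these compounds alone.

Measured in a functional assay on MCF7 cells (Homo sapiens) for antiproliferative activity, read by MTT assay, with a stated time of 72 h; a higher number here means a weaker inhibitor, a lower number a stronger inhibitor:
- compound 1 `COc1ccc(-c2ncnn2-c2cc(OC)c(OC)c(OC)c2)cc1`: 360 nM
- compound 2 `COc1cc(-c2ncnn2-c2ccc(F)cc2)cc(OC)c1OC`: > 10000 nM (a limit)
- compound 3 `COc1cc(-c2ncnn2-c2ccc([N+](=O)[O-])cc2)cc(OC)c1OC`: > 10000 nM (a limit)

Compound 1 is the only one of the three with a readable number, 360 nM. Compound 2 reports only a limit, > 10000 nM. Compound 3 also reports only a limit, > 10000 nM. Among the measured compounds shown here, the one measured comparison is a step that the two limits leave unreadable from compound 2 to compound 3, so it offers no size to carry over. The wider picture is the limit of > 10000 nM in this assay, at which 2 of the 3 values shown sit.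

Compound 4 `COc1cc(-n2ncnc2-c2ccc(Cl)c(Cl)c2)cc(OC)c1OC` keeps the core of compound 1 and exchanges one group: 3,4-dichlorophenyl in place of 4-methoxyphenyl on an aromatic carbon. In words, 3,4-dichlorophenyl takes the place of 4-methoxyphenyl. For the measured compounds named here, no measured step covers this exchange, so the data give no direct size for it.

Compound 1 at 360 nM is the only one of the three with a readable number, so a weakening seems more likely than a gain, though this is a cautious expectation rather than a firm reading. The expected change is a 5.6-fold higher number from compound 1 to compound 4 (0.74 log units; beyond the scatter), and its size is very uncertain. In this assay the estimate for compound 4 is 2000 nM, with an expected range from 300 nM to 10000 nM.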

Compound 4, half-maximal inhibitory concentration: > 10000 nM
Compound 4 ended at the assay's limit (the forecaster's own chance of this, stated with the estimate: 25%); middle value at least 5.0-fold (0.69 log units) away from the limit.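

In this assay, the place on the five-membered ring that carries 4-methoxyphenyl in compound 1 proves sensitive to what sits there: exchanging that group for 3,4-dichlorophenyl gives an at least 27-fold higher number from compound 1 to compound 4 (1.44 log units; beyond the scatter). The value of compound 4, > 10000 nM, is a limit, so this step gives only the smallest size the change could have. The earlier compounds offered no readable step at all, and this one shows that keeping an aromatic ring of carbon only at this place is not enough to hold a readable number, even though 4-methoxyphenyl carries a hydrogen-bond acceptor and 3,4-dichlorophenyl carries none; compound 1 remains the only compound with a number, and the wider picture is: the limit of > 10000 nM in this assay, at which 3 of the 4 values shown sit.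

With both the methoxy group and the two chlorine atoms changing in one exchange, the compounds shown cannot tell whether losing the first or adding the second matters more. On these data alone, whether a 4-hydroxyphenyl or a 4-ethoxyphenyl group at this same place would keep a readable number, and how close it would come to compound 1, stays open.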